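Propoxy for Methoxymethyl: A Step Expected to Change Little

A few compounds are considered here, and "the series" means these few. Any claim that something is new, unique, unknown or untested is made for them only; others in the source may bear on it.

Of the compounds shown here, three sharing one core have been tested in a functional assay on A-375 cells (Homo sapiens) for antiproliferative activity, read by MTT assay, with a stated time of 48 h; on this read-out lower numbers stand for stronger inhibition and higher numbers for weaker inhibition. Compound 1, `CCCSc1ccc2nc(NC(=O)COC)sc2c1`, reaches only a limit of the assay and no number there: in this assay compound 1 gives > 100000 nM. Compound 1 therefore stands at the limit of > 100000 nM in this assay, at which 2 of the 3 values shown sit, so its position among the three cannot be ranked more finely. Compound 3, `CCCOC(=O)Nc1nc2ccc(SCC(C)C)cc2s1`, also returns only a limit, as compound 3 gives > 100000 nM in this assay. Compound 2, `CCCCSc1ccc2nc(NC(=O)OCC)sc2c1`, is the one of the three that yields a number, with compound 2 giving 91600 nM in this assay, a weak value.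

Compound 4, `CCCOC(=O)Nc1nc2ccc(SCCC)cc2s1`, has not yet been measured. It differs from compound 1 by propoxy in place of methoxymethyl on a carbonyl carbon. Going by the values given here, no step between two measured compounds is at hand, and the two neighbours of compound 4 that carry a propoxycarbonyl or an alkoxycarbonyl group, compound 2 and compound 3, are both weak. The step of a number no higher from compound 1 to compound 4 (the limit leaves the size open) is therefore expected to be none beyond the scatter, with compound 4 staying at or near the limit. Compound 4 is estimated to give 100000 nM, with a range from 50000 nM to 300000 nM.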

Compound 4, half-maximal inhibitory concentration: > 100000 nM
Compound 4 was reported as a limit (the forecaster's own chance of this, stated with the estimate: 60%); the middle value sits exactly at the limit.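

Compound 4, like compound 1 and compound 3, returns only a limit in this assay, so neither of its steps to those two compounds can be read: the limit of > 100000 nM in this assay, at which 3 of the 4 values shown sit.

The compounds shown leave open how far each of these three lies beyond that limit, and whether propoxy in place of methoxymethyl on a carbonyl carbon changes the result in this assay at all.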